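Removing a Methyl: Expected Cytotoxicity of Compound 4

A few compounds are considered here, and "the series" means these few. Any claim that something is new, unique, unknown or untested is made for them only; others in the source may bear on it.

Compound 1, `COc1cc(C(=N)NC(C)C)cc2cc(-c3ccc(C(=N)NC(C)C)cc3)oc12`: in an ADME assay on L6 cells (Rattus norvegicus) for cytotoxicity (a lower number here means a stronger inhibitor, a higher number a weaker inhibitor), compound 1 gives > 190000 nM, a limit of the assay and not a number.
Compound 2, `CC(C)NC(=N)c1ccc(-c2cc3cc(C(=N)NC(C)C)cc(O)c3o2)cc1`: compound 2 gives > 185000 nM, again a limit and not a number.
Compound 3, `COc1cc(C(=N)NC(C)C)ccc1-c1cc2cc(C(=N)NC(C)C)ccc2o1`: compound 3 gives 98100 nM.

The change from compound 1 to compound 2 is hydrogen in place of methyl on an oxygen on an aromatic ring, and its step is a step that the two limits leave unreadable from compound 1 to compound 2, because both ends sit at limits, the limit of > 190000 nM in this assay, at which 1 of the 3 values shown sits, and (the limit of > 185000 nM in this assay, at which 1 of the 3 values shown sits). Compound 4, `CC(C)NC(=N)c1ccc(-c2cc3cc(C(=N)NC(C)C)ccc3o2)c(O)c1`, carries the same change on the core of compound 3, (hydrogen in place of methyl on an oxygen on an aromatic ring); the difference between the two cores is not broken down here. Since the measured step gives no readable size, compound 4 is expected to stay close to compound 3, a step of a 1.0-fold higher number from compound 3 to compound 4 (0.01 log units; within the scatter). The estimate for compound 4 is 100000 nM, expected between 40000 nM and 250000 nM.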

Compound 4, half-maximal inhibitory concentration: > 183000 nM
Compound 4: only a limit was reported; the forecaster's own chance of this, stated with the estimate: 30%; at least 1.8-fold (0.26 log units) between middle value and limit.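

In this assay compound 4 gives > 183000 nM and this is a limit of the assay, not a number. From the compounds shown here alone, on the core of compound 3, the change of methoxy to hydroxy is an at least 1.8-fold higher number from compound 3 to compound 4 (0.27 log units; that floor lies within the scatter) and its true size stays unknown, so this shows only a floor that does not clear the usual scatter. Going by these compounds alone, the same change from compound 1 to compound 2 cannot be read, with limits at both ends, so the two cores offer no pair of sizes to compare, and nothing here shows whether the change carries the same size from one core to the other.

The compounds shown leave open how an ethyl or longer chain on that oxygen would read in this assay on either core. Going by these compounds, an amine in place of the hydroxy stays equally open.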